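Two chlorines change places on a trimethoxybenzohydrazone

The source may hold more compounds than are shown below. What is called first, only, known or untested is meant among the compounds shown, and "the series" means these compounds.

Compounds measured in a functional assay on PC-3 cells (Homo sapiens) for antiproliferative activity, read by MTT assay, tested at 1 uM; a higher number here means a stronger effect of the compound at the concentration tested, a lower number a weaker effect:
compound 1, `COc1ccc(/C=N/NC(=O)c2cc(OC)c(OC)c(OC)c2)c(OC)c1`, gives 10%
compound 2, `COc1cc(C2=NN(C(C)=O)C(c3cc(Cl)cc(Cl)c3)O2)cc(OC)c1OC`, gives 52.7%
compound 3, `COc1cc(C(=O)N/N=C/c2c(Cl)cccc2Cl)cc(OC)c1OC`, gives 43%

Among these three numbers compound 3 stands second highest. Its nearest neighbour is compound 2, whose value lies slightly higher, yet the gap between the two falls within the usual scatter of this assay, so neither can be called the stronger of the pair. The furthest is compound 1, whose value lies well below that of compound 3, a gap beyond the scatter.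

The next compound to be measured is compound 4, `COc1cc(C(=O)N/N=C/c2ccc(Cl)c(Cl)c2)cc(OC)c1OC`. It keeps the whole of compound 3 and differs from it in one place: 3,4-dichlorophenyl in place of 2,6-dichlorophenyl on a carbon with a double bond to nitrogen. The two have the same atoms, joined differently.

Within the data shown here, no pair of measured compounds differs in exactly one place, so no measured step offers a guide for this change. Compound 3 and compound 2 both carry two chlorines on their aryl ring and give similar values, which suggests that the arrangement of the chlorines is not decisive here. Compound 4 is therefore expected to stay close to compound 3, with the step of a number 3 percentage points lower from compound 3 to compound 4 (within the scatter) expected to lie within the scatter. The estimate for compound 4 in this assay is 40%, with an expected range from 15% to 65%.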

Compound 4, a percentage reported as inhibition, at one concentration (the size of the read-out at that concentration, not a potency): 13.5%
Compound 4: middle estimate off by 26.5 percentage points, on the high side; the measured number lies below the stated range.
By their numbers in this assay, from the lowest: compounds 1 and 4 (each within the scatter of the next); then compounds 3 and 2 (each within the scatter of the next).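

In this assay, among these compounds, exchanging 2,6-dichlorophenyl for 3,4-dichlorophenyl on the carbon with a double bond to nitrogen produces a number 29.5 percentage points lower from compound 3 to compound 4 (beyond the scatter), the only step between measured compounds that differ in one place. The two groups match in every count: each has 8 heavy atoms, one six-membered aromatic ring of carbon only, no hydrogen-bond donors or acceptors and no net charge. Among the compounds shown here, this position is therefore sensitive to how the two chlorines are arranged on the ring, not merely to whether they are present, a point that no earlier compound could show, since none of them formed a one-place pair.

This single step compares only two arrangements of two chlorines, so it leaves open how the position would respond to a single chlorine or to a different group on the ring, such as a nitrile, a trifluoromethyl group or an amine. Why the arrangement matters also stays open, as nothing available here bears on the cause of this step.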